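Sulfonyl in Place of Acetyl on the Shared Core

The source may hold more compounds than are shown below. What is called first, only, known or untested is meant among the compounds shown, and "the series" means these compounds.

Measured compounds:
compound 1 `CC(=O)N(C)c1ccc2[nH]c(-c3n[nH]c4ccccc34)cc2n1` – 10300 nM
compound 2 `CN(C(=O)c1ccccc1)c1ccc2[nH]c(-c3n[nH]c4ccccc34)cc2n1` – 8580 nM

In a functional assay on KB cells (Homo sapiens) for antiproliferative activity, read by MTT assay, with a stated time of 72 h (a lower number here means a stronger inhibitor, a higher number a weaker inhibitor), compound 1 gives 10300 nM, the highest of the two numbers; compound 2 gives 8580 nM, and the step of a 1.2-fold lower number from compound 1 to compound 2 (0.08 log units; within the scatter) is within the scatter. Compound 3 `CN(c1ccc2[nH]c(-c3n[nH]c4ccccc34)cc2n1)S(=O)(=O)c1ccc(Br)cc1` differs from compound 1 by (4-bromophenyl)sulfonyl in place of acetyl on a nitrogen on an aromatic ring. For the measured compounds named here, the only measured step, a 1.2-fold lower number from compound 1 to compound 2 (0.08 log units; within the scatter), swaps a group on the carbonyl carbon and says little about a change to a sulfonyl group, so the expected step of a 1.7-fold lower number from compound 1 to compound 3 (0.23 log units; within the scatter) rests on thin ground. Compound 3 is estimated at 6000 nM, with a range from 1500 nM to 25000 nM.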

Compound 3, half-maximal inhibitory concentration: 7150 nM
The estimate for compound 3 lay 1.2-fold (0.08 log units) below the measured number; low and high end bracket the measured number.
By their numbers in this assay, from the lowest: compounds 3, 2 and 1 (each within the scatter of the next).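

In this assay, (4-bromophenyl)sulfonyl in place of acetyl on a nitrogen on an aromatic ring gives a 1.4-fold lower number from compound 1 to compound 3 (0.16 log units; within the scatter), and the same group in place of benzoyl gives a 1.2-fold lower number from compound 2 to compound 3 (0.08 log units; within the scatter). This position, so far shown only with carbonyl groups, thus also accepts a sulfonyl group carrying a brominated aromatic ring, with all three numbers within the scatter of one another. Nothing at hand explains this result. The compounds shown leave open whether an amine, a carboxylic acid or a longer chain at this position would move the number beyond the scatter. They also leave open what the bromine contributes.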